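This account rests on a few compounds, and the source may have more. Where it says the series, first, only, none or still open, it means among the compounds named here.

Compound 1 `Cn1c(/C=C2\SC(=O)N(CC(=O)Nc3nc(-c4ccccc4)cs3)C2=O)nc2ccccc21` in a functional assay on MDA-MB-231 cells (Homo sapiens) for inhibition, read by MTT assay, with a stated time of 48 h (a lower number here means a stronger inhibitor, a higher number a weaker inhibitor), gives 29200 nM. Compound 3 `CCn1c(/C=C2\SC(=O)N(CC(=O)Nc3nc(-c4ccccc4)cs3)C2=O)nc2ccccc21` returns only a limit of this assay, > 50000 nM. The change between them is methyl in place of hydrogen on a saturated chain carbon bound to an aromatic nitrogen, and it made an at least 1.7-fold higher number from compound 1 to compound 3 (0.23 log units; that floor lies within the scatter); the floor of that step rests on (the limit of > 50000 nM in this assay, at which 2 of the 3 values shown sit). Compound 2 `CCn1c(/C=C2\SC(=O)N(CC(=O)N3CCc4cc(OC)c(OC)cc4C3)C2=O)nc2ccccc21` likewise gives only a limit in this assay, > 50000 nM. The cores of compound 1 and compound 2 differ, and that difference is not broken down here. Compound 4 `COc1cc2c(cc1OC)CN(C(=O)CN1C(=O)S/C(=C\c3nc4ccccc4n3C(C)C)C1=O)CC2` carries the same kind of change relative to compound 2, (methyl in place of hydrogen on a saturated chain carbon bound to an aromatic nitrogen and a saturated chain carbon); around the place, the saturated chain carbon is here bound to an aromatic nitrogen and a saturated chain carbon rather than to an aromatic nitrogen alone. Since the earlier change gave an at least 1.7-fold higher number from compound 1 to compound 3 (0.23 log units; that floor lies within the scatter) and did not lower the number, compound 4 is expected to land around 60000 nM, between 30000 nM and 120000 nM, meaning a step that the limit leaves unreadable from compound 2 to compound 4, most likely reported again only as a limit.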

Compound 4, half-maximal inhibitory concentration: 30600 nM
Estimate against measurement, compound 4: 2.0-fold (0.29 log units) above; the range from low to high includes it.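

In this assay, going from ethyl to isopropyl makes an at least 1.6-fold lower number from compound 2 to compound 4 (0.21 log units; that floor lies within the scatter). The direction of this methyl change therefore does not carry over from one core to the other among the compounds shown: the same change on two cores in this assay, an at least 1.7-fold higher number (0.23 log units; that floor lies within the scatter) from compound 1 to compound 3 and an at least 1.6-fold lower number (0.21 log units; that floor lies within the scatter) from compound 2 to compound 4, at least 2.7-fold (0.44 log units) apart, beyond the scatter of two such steps Both steps are only floors set by a limit, so their true sizes and the true gap between them remain unread, and the pair of cores gives no general rule for the series: the limit of > 50000 nM in this assay, at which 2 of the 4 values shown sit.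

Still open, going by these compounds, is whether isopropyl on the core of compound 1 would read like compound 4. Also open, on these data alone, is how a longer chain, or a chain carrying an amine, would read in this assay in place of ethyl or isopropyl.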